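This account rests on a few compounds, and the source may have more. Where it says the series, first, only, none or still open, it means among the compounds named here.

Measured so far in an ADME assay on HEL cells (Homo sapiens) for cytotoxicity, with a stated time of 3 days; on this read-out higher numbers stand for lower toxicity in this test and lower numbers for higher toxicity in this test:
compound 1, `Cc1cn([C@@H]2O[C@H](CO[Si](C)(C)C(C)(C)C)[C@@]3(OS(=O)(=O)C=C3NC(=O)NC(=O)c3ccccc3)[C@H]2O[Si](C)(C)C(C)(C)C)c(=O)n(C)c1=O`, > 200000 nM
compound 2, `Cc1cn([C@@H]2O[C@H](CO[Si](C)(C)C(C)(C)C)[C@@]3(OS(=O)(=O)C=C3NC(=O)NC(=O)c3ccccc3)[C@H]2O)c(=O)n(C)c1=O`, 22000 nM

Compound 1 gives only a limit of the assay in this assay, > 200000 nM, so its standing on the numbers is open-ended at the less toxic side (the limit of > 200000 nM in this assay, at which 1 of the 2 values shown sits). Compound 2 sits at 22000 nM. Going by the values given here, the one measured step, an at least 9.0-fold lower number from compound 1 to compound 2 (0.95 log units; beyond the scatter), swaps a hydrogen for a group of 7 heavy atoms (6 carbon, 1 silicon; no ring) on an oxygen on a saturated carbon and moves the number downward, beyond the scatter.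

Compound 3, `Cc1cn([C@@H]2O[C@H](COCc3ccccc3)[C@@]3(OS(=O)(=O)C=C3NC(=O)NC(=O)c3ccccc3)[C@H]2O[Si](C)(C)C(C)(C)C)c(=O)n(C)c1=O`, differs from compound 1 by a group of 7 heavy atoms (7 carbon; one six-membered aromatic ring of carbon only) in place of a group of 7 heavy atoms (6 carbon, 1 silicon; no ring), on an oxygen on a saturated carbon, at the oxygen on a saturated carbon whose other neighbours are a saturated chain carbon. Among the compounds with values here, no measured step addresses an exchange of this kind at this position; the step from compound 1 to compound 2 concerns a different oxygen and a loss of the whole group rather than a replacement by benzyl. A group of similar size remains in place in compound 3, so no step beyond the scatter is expected in this assay, and the number is expected to stay close to the limit region of compound 1 with an at least 1.3-fold lower number from compound 1 to compound 3 (0.12 log units; that floor lies within the scatter). Compound 3 is therefore estimated at 150000 nM, range 40000 nM to 400000 nM, pending the measurement.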

Compound 3, half-maximal cytotoxic concentration: > 50000 nM
Compound 3 ended at the assay's limit; the forecaster's own chance of this, stated with the estimate: 45%; the middle value lies beyond the limit too.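

In this assay compound 3 gives > 50000 nM, which is a limit of the assay. Going by these compounds alone, compound 1 gives > 200000 nM, also a limit, so no step between compound 1 and compound 3 can be read. The compounds shown leave open whether benzyl and the group it replaces, on an oxygen on a saturated carbon, differ at all on this read-out.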